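Bromo Analogue Where Three Compounds Sit at the Limit

A few compounds are considered here, and "the series" means these few. Any claim that something is new, unique, unknown or untested is made for them only; others in the source may bear on it.

Compound 2 `O=C(CCCc1ccccc1)Nc1nc2ccccc2c(=O)s1` is the reference point. In an assay on CHO cells for displacement of a labelled ligand from adenosine receptor A3 (Homo sapiens), read by scintillation counting, with a stated time of 60 min (a higher number here means a weaker inhibitor, a lower number a stronger inhibitor), compound 2 gives > 1000 nM, which is a limit of the assay rather than a number. Compound 1 `O=C(CCCc1ccccc1)Nc1nc2ccc(Cl)cc2c(=O)s1` carries a chloro on the shared core. In this assay compound 1 gives > 1000 nM, again a limit. Compound 3 `O=C(CCc1ccccc1Br)Nc1nc2ccccc2c(=O)s1` carries a 2-bromophenyl at the end of the chain. In this assay compound 3 gives > 1000 nM, also a limit. The step that the two limits leave unreadable from compound 1 to compound 2 and the step that the two limits leave unreadable from compound 2 to compound 3 cannot be read, since (the limit of > 1000 nM in this assay, at which 3 of the 3 values shown sit). Compound 4 `O=C(CCCc1ccccc1)Nc1nc2ccc(Br)cc2c(=O)s1` differs from compound 2 by bromo in place of hydrogen on an aromatic carbon. Among the compounds with values here, no measured step shows this change helping. The step from compound 2 to compound 4 is expected to be a step that the limit leaves unreadable from compound 2 to compound 4. Compound 4 is therefore estimated at 3000 nM, within 1000 nM to 10000 nM.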

Compound 4, inhibition constant: > 1000 nM
Compound 4: no number, only a limit; the forecaster's own chance of this, stated with the estimate: 85%; the middle value does not contradict the limit.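

In this assay compound 4 sits at a limit, as do compound 1 and compound 2, so no step among these three compounds can be read: the limit of > 1000 nM in this assay, at which 4 of the 4 values shown sit.

The compounds shown leave open whether hydrogen, chloro or bromo on that aromatic carbon makes any difference, and how strongly any of them really binds.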